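The source may report more compounds than this note shows. Statements on the series, on what has been measured and on what is new or still open speak of the compounds shown alone.

Two compounds of the series carry numbers in an assay on CHO cells for displacement of a labelled ligand from 5-hydroxytryptamine receptor 1B (Homo sapiens); on this read-out lower numbers stand for stronger inhibition and higher numbers for weaker inhibition. Compound 1 `CC(C)=CCCN(C)C1CCN(CCCc2c[nH]c3ccc(-n4cnnc4)cc23)CC1` gives 24 nM in this assay, the lowest of the two numbers. Compound 2 `OC[C@H](NC1CCN(CCCc2c[nH]c3ccc(Cn4cncn4)cc23)CC1)c1ccccc1` gives 1300 nM in this assay, a gap beyond the scatter, but the two compounds differ in more than one place, so nothing of that gap can be tied to a single change. Compound 3 `c1cncc(CNC2CCN(CCCc3c[nH]c4ccc(-n5cnnc5)cc34)CC2)c1` is not yet measured. It differs from compound 1 in one place (((pyridin-3-yl)methyl)amino in place of methyl(4-methylpent-3-en-1-yl)amino on a saturated ring carbon). Among the measured compounds shown here, no step between measured compounds that differ in one place is available, so the size of this change is open; the only other number in hand, that of compound 2, stands well above compound 1. Compound 3 is therefore expected to land somewhat above compound 1, with a step of a 3.3-fold higher number from compound 1 to compound 3 (0.52 log units; beyond the scatter) of modest size. Compound 3 is estimated at 80 nM, in a range of 20 nM to 400 nM.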

Compound 3, half-maximal inhibitory concentration: 140 nM
Beside the measured number, compound 3's estimate is 1.8-fold (0.24 log units) below it; the measured number falls inside the stated range.
By their numbers in this assay, from the lowest: compound 1; then compound 3; then compound 2.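

In this assay, the group on the saturated ring carbon now has a measured step: a 5.8-fold higher number from compound 1 to compound 3 (0.77 log units; beyond the scatter) with ((pyridin-3-yl)methyl)amino in place of methyl(4-methylpent-3-en-1-yl)amino. This position therefore responds to the exchange even though the heavy-atom count stays the same, and the higher number comes with a six-membered aromatic ring, a hydrogen-bond donor and the loss of the double bond, which this single step cannot separate. No measurement in hand accounts for the size of the step.

Left open is whether benzylamino or methyl((pyridin-3-yl)methyl)amino on this carbon would read closer to compound 1 or to compound 3. Such groups would show whether the aromatic ring, its hetero atom or the amine hydrogen tracks with the step.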